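A Single Methyl Added to Compound 2

A few compounds are considered here, and "the series" means these few. Any claim that something is new, unique, unknown or untested is made for them only; others in the source may bear on it.

Three compounds built on a shared core are considered here: compound 1 (`Cc1ccccc1S(=O)(=O)N1CCC(CCCC(=O)NO)CC1`), compound 2 (`O=C(CCCC1CCN(S(=O)(=O)c2ccc3ccccc3c2)CC1)NO`) and compound 3 (`Cc1cc(S(=O)(=O)N2CCC(CCCC(=O)NO)CC2)cc2ccccc12`). In a functional assay on HCT-116 cells (Homo sapiens) for inhibition, read by resazurin assay, with a stated time of 5 days (a higher number here means a weaker inhibitor of growth, a lower number a stronger inhibitor of growth), compound 1 has the entry "not determined" (no result reported), so it offers no number for comparison. In this assay, compound 2 gives 1900 nM. For the measured compounds named here, that is the only number available, so it cannot yet be ranked against any other compound.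

Compound 3 has not been measured. It departs from compound 2 in one place: methyl in place of hydrogen on an aromatic carbon. Going by the values given here, no step between measured compounds shows what any change does in this assay, so the expectation rests on the value of compound 2, 1900 nM, and on the small size of this change. No shift beyond the scatter is expected, and no firm direction can be given. The estimated step of a 1.1-fold lower number from compound 2 to compound 3 (0.05 log units; within the scatter) therefore stays within the scatter. Compound 3 is estimated at 1700 nM, with an expected range of 650 nM to 4500 nM.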

Compound 3, concentration for 50% growth inhibition: 17300 nM
Compound 3: middle estimate off by 10-fold (1.01 log units), on the low side; measured number outside the range, above it.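

In this assay, for the compounds shown here, this is the first readable step on the shared core: methyl in place of hydrogen on an aromatic carbon gives a 9.1-fold higher number from compound 2 to compound 3 (0.96 log units; beyond the scatter) and moves the compound towards weaker inhibition of growth. It shows that this position, ortho to a fused ring and meta to a large group, is not indifferent to change, since one added carbon with no hydrogen-bond donors or acceptors and no net charge is enough to carry the number beyond the scatter. Nothing available bears on what lies behind this shift.

The compounds shown leave open whether the shift belongs to methyl itself or would also follow from another group at this carbon, such as a fluorine atom, a methoxy group or an amine. They also leave open whether methyl on other aromatic carbons of the fused system would give a step of similar size or direction, since this single pair speaks for one position and one change only.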